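Swapping a nitro ring for a chloro ring

This account rests on a few compounds, and the source may have more. Where it says the series, first, only, none or still open, it means among the compounds named here.

Compound 2 `Nc1ccccc1NC(=O)CCCNCC(=O)Nc1cccc([N+](=O)[O-])c1` and compound 1 `Nc1ccccc1NC(=O)CCCNCC(=O)Nc1ccc(Cl)cc1` share one core and differ only in the ring carried on an amide-type nitrogen. In a functional assay on the whole organism (Ehrlich cells, Mus musculus) for antiproliferative activity, with a stated time of 24 h, at a dose of 0.2 mmol/kg by the intraperitoneal route (a lower number here means less inhibition, a higher number more inhibition at the dose given (going by the name of the read-out)), compound 1 gives 75%, while compound 2 gives 36%, the lower of the two numbers measured. Among the compounds with values here, the single measured step, a number 39 percentage points lower from compound 1 to compound 2 (beyond the scatter), is large and is the only comparison that bears on the next change. Compound 3 `Nc1ccccc1NC(=O)CCCNCC(=O)Nc1ccccc1Cl` has not been measured; it differs from compound 2 in one place: 2-chlorophenyl in place of 3-nitrophenyl on an amide-type nitrogen. This change runs the measured step in reverse, but the chlorine now sits in a 2-chlorophenyl rather than the 4-chlorophenyl of compound 1, for which no number exists. A rise is therefore expected, a number 24 percentage points higher from compound 2 to compound 3 (beyond the scatter), with a wide range. Compound 3 is estimated to give about 60%, between 35% and 85%.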

Compound 3, a percentage reported as inhibition, in the whole organism at one dose (the size of the read-out at that dose, not a potency): 12.7%
Estimate against measurement, compound 3: 47.3 percentage points above; measured number below the stated range.
By their numbers in this assay, from the lowest: compound 3; then compound 2; then compound 1.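

Within this assay the place of the chlorine on the ring proves decisive: a number 62.3 percentage points lower from compound 1 to compound 3 (beyond the scatter) comes with 2-chlorophenyl in place of 4-chlorophenyl, although the ring and its atoms stay the same. A chlorine alone therefore does not secure a high number, and a number 23.3 percentage points lower from compound 2 to compound 3 (beyond the scatter) shows that 2-chlorophenyl also falls short of 3-nitrophenyl. Nothing shown here gives a reason for these differences.

Going by these compounds, with only these rings to compare on the amide-type nitrogen, it stays open how 3-chlorophenyl or 4-nitrophenyl would behave, and these would help separate the choice of group from its place on the ring. Also open, on these data alone, is whether an unsubstituted phenyl, or a phenyl carrying a methoxy group or an amine, would come closer to compound 1 or to compound 3.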